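This account rests on a few compounds, and the source may have more. Where it says the series, first, only, none or still open, it means among the compounds named here.

Compound 1 `COc1ccn2c(-c3ccc(NC(=O)c4ccc([N+](=O)[O-])o4)cc3)cnc2c1` gives 720 nM in a functional assay on AGS cells (Homo sapiens) for antiproliferative activity, read by CCK-8 assay, with a stated time of 72 h; a higher number here means a weaker inhibitor, a lower number a stronger inhibitor. Compound 2 `COc1ccn2c(-c3ccc(NC(=O)c4ccc([N+](=O)[O-])o4)c(C)c3)cnc2c1` gives 430 nM in this assay. Compound 3 `COc1ccn2c(-c3ccc(NC(=O)c4ccc([N+](=O)[O-])o4)c(OC)c3)cnc2c1` gives 3880 nM in this assay.

Compound 3 has the highest number of the three, so it is the weakest inhibitor here: a 5.4-fold higher number from compound 1 to compound 3 (0.73 log units; beyond the scatter) and a 9.0-fold higher number from compound 2 to compound 3 (0.96 log units; beyond the scatter) both lie beyond the scatter, while a 1.7-fold lower number from compound 1 to compound 2 (0.22 log units; within the scatter) does not. Compound 4 `COc1ccn2c(-c3ccc(NC(=O)c4ccc([N+](=O)[O-])o4)c(C(F)(F)F)c3)cnc2c1` differs from compound 3 by trifluoromethyl in place of methoxy on an aromatic carbon. Among the measured compounds shown here, no measured step places a trifluoromethyl at this position, so the expectation rests on the methoxy having been the one harmful substituent and on the methyl being tolerated. Compound 4 is therefore expected to give a lower number than compound 3, a 3.9-fold lower number from compound 3 to compound 4 (0.59 log units; beyond the scatter), though the size is uncertain. The estimate for compound 4 is 1000 nM, between 300 nM and 4000 nM.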

Compound 4, half-maximal inhibitory concentration: 710 nM
The estimate for compound 4 lay 1.4-fold (0.15 log units) above the measured number; the measured number falls inside the stated range.
By their numbers in this assay, from the lowest: compounds 2, 4 and 1 (each within the scatter of the next); then compound 3.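

Trifluoromethyl recovers what methoxy lost at this position (a 5.5-fold lower number from compound 3 to compound 4 (0.74 log units; beyond the scatter)), even though it carries more heavy atoms than methoxy. It also cannot be told apart from the other two groups (a 1.0-fold lower number from compound 1 to compound 4 (0.01 log units; within the scatter); a 1.7-fold higher number from compound 2 to compound 4 (0.22 log units; within the scatter)), so among the four groups tried here, only methoxy stands out from hydrogen, methyl and trifluoromethyl. No measurement shown here explains this difference between the groups.

Still open, going by these compounds, is how a hydroxyl, an amine or a longer chain such as ethoxy would fare at this position, and whether methoxy stands out in the same way on other carbons of this ring.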